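The source may report more compounds than this note shows. Statements on the series, on what has been measured and on what is new or still open speak of the compounds shown alone.

Among the compounds with values here, compound 2 `C=CCc1cc(C(C)=O)c(O)cc1OCCCCC#N` gives 92% in an assay on isolated protein for inhibition of leukotriene B4 receptor 1 (Homo sapiens), tested at 10 uM (a lower number here means less inhibition, a higher number more inhibition at the concentration tested (going by the name of the read-out)), the higher of the two numbers measured so far. Within the data shown here, compound 1 `CC(=O)c1cc(CC(C)O)c(OCCCCC#N)cc1O` gives 10% in this assay, and the only measured step, a number 82 percentage points higher from compound 1 to compound 2 (beyond the scatter), alters a different part of the shared core, not the saturated chain carbon bound to a carbonyl carbon. Compound 3 `C=CCc1cc(C(=O)CCCCCCCCC)c(O)cc1OCCCCC#N` differs from compound 2 by octyl in place of hydrogen on a saturated chain carbon bound to a carbonyl carbon. Among the measured compounds shown here, no measured step concerns that position, and the expectation is a change of a number 12 percentage points lower from compound 2 to compound 3 (beyond the scatter). Compound 3 is therefore estimated at 80%, within a range from 45% to 98%.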

Compound 3, a percentage reported as inhibition, at one concentration (the size of the read-out at that concentration, not a potency): 10%
Beside the measured number, compound 3's estimate is 70 percentage points above it; measured number outside the range, below it.
By their numbers in this assay, from the lowest: compounds 1 and 3 (each within the scatter of the next); then compound 2.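

In this assay, within the data shown here, the first measured change at the saturated chain carbon bound to a carbonyl carbon, octyl in place of hydrogen, gives a number 82 percentage points lower from compound 2 to compound 3 (beyond the scatter) and removes nearly all the inhibition seen for compound 2 at the concentration tested. This position is therefore not free to carry any group, at least not one as long as octyl. No measurement here gives a reason for the loss.

With only hydrogen and octyl compared at this position, the compounds shown leave open where between them the inhibition falls away. From the compounds shown here alone, whether an ethyl or butyl group would keep it, or whether an amine or a carboxylic acid would be accepted there, also remains unknown.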